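This account rests on a few compounds, and the source may have more. Where it says the series, first, only, none or still open, it means among the compounds named here.

Compound 3 `Cc1cccc(OCC2=NCCO2)c1` gives 25% in a toxicity assay on the whole organism with Rattus norvegicus as the target, at a dose of 400 mg/kg by the oral route (on this read-out higher numbers stand for a stronger effect at the one dose given and lower numbers for a weaker effect), the second highest of three numbers: compound 1 `Clc1ccc(OCC2=NCCO2)cc1` gives 12%, and compound 2 `Cc1cc(OCC2=NCCO2)ccc1Cl` gives 40%. The two measured steps were both modest, a number 28 percentage points higher from compound 1 to compound 2 (beyond the scatter) and a number 15 percentage points lower from compound 2 to compound 3 (beyond the scatter). Compound 4 `O=[N+]([O-])c1cccc(OCC2=NCCO2)c1` differs from compound 3 in one place: nitro in place of methyl on an aromatic carbon. Among the measured compounds shown here, neither measured step exchanges a methyl for a nitro, so no step bears directly on this change; the steps measured so far suggest only that a single change on this ring shifts this assay by a modest amount. A change of modest size in either direction is therefore expected, with the estimate for compound 4 centred on 25%, in the range 8% to 45%, which means an expected step of no change at the digits printed from compound 3 to compound 4 (within the scatter).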

Compound 4, a percentage reported as activity, at one dose (the size of the read-out at that dose, not a potency): 80%
Beside the measured number, compound 4's estimate is 55 percentage points below it; measured number outside the range, above it.
By their numbers in this assay, from the lowest: compound 1; then compound 3; then compound 2; then compound 4.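

At this aromatic carbon, meta to a group of 7 heavy atoms, nitro in place of methyl gives a number 55 percentage points higher from compound 3 to compound 4 (beyond the scatter) in this assay. This is the only large step shown, so a single change on this ring can move the number much further than the modest earlier steps indicated. Nothing available explains the size of this step. Still open, from the compounds shown here alone, is whether an amine or a carboxylic acid at this carbon would shift the number as far, and whether nitro in place of the chloro of compound 1 would do the same.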